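Oxazolidinedione to thiazolidinedione ylidene swap: solubility notes

The source may hold more compounds than are shown below. What is called first, only, known or untested is meant among the compounds shown, and "the series" means these compounds.

Measured compounds:
compound 1, `C/C(=C1/OC(=O)NC1=O)C(c1ccc(-c2ccc3cccc(F)c3c2)[nH]c1=O)C(C)C`; in a physicochemical assay for solubility, measured as kinetic solubility, at pH 2 (on this read-out lower numbers stand for lower solubility and higher numbers for higher solubility), compound 1 gives 12700 nM
compound 2, `CC(C)[C@@H](c1ccc(-c2ccc3cccc(F)c3c2)[nH]c1=O)[C@@H]1OC(=O)NC1=O`; in this assay compound 2 gives 6900 nM
compound 3, `CC(C)[C@H](C[C@@H]1OC(=O)NC1=O)c1ccc(-c2ccc3cccc(F)c3c2)[nH]c1=O`; in this assay compound 3 gives 25100 nM

Compound 1 stands second highest of the three numbers in this assay; the nearest is that of compound 2 and the furthest that of compound 3, and both gaps lie within the scatter, so no order among the three can be read from the values. For the measured compounds named here, the one step between measured compounds that differ in a single place is a 3.6-fold higher number from compound 2 to compound 3 (0.56 log units; beyond the scatter), which concerns the chain between the saturated chain carbon and the ring, not the ring itself.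

Compound 4, `CC(C)C(/C=C1\SC(=O)NC1=O)c1ccc(-c2ccc3cccc(F)c3c2)[nH]c1=O`, differs from compound 1 by a group of 8 heavy atoms (4 carbon, 1 nitrogen, 2 oxygen, 1 sulfur; one five-membered non-aromatic ring with 2 hetero atoms) in place of a group of 9 heavy atoms (5 carbon, 1 nitrogen, 3 oxygen; one five-membered non-aromatic ring with 2 hetero atoms), on a saturated chain carbon bound to an aromatic carbon and a saturated chain carbon. The leaving group carries 3 oxygen and no sulfur, the entering group 2 oxygen and 1 sulfur, with donor and acceptor counts unchanged. Going by the values given here, no measured step bears on this kind of change; the step from compound 2 to compound 3 addresses chain length only, and the three measured compounds all carry the same oxygen-bearing ring. With nothing in the data pointing either way, no step beyond the scatter is expected in this assay.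

For compound 4 the expected value in this assay is 11000 nM, with a range from 4000 nM to 28000 nM. This estimate corresponds to an expected 1.2-fold lower number from compound 1 to compound 4 (0.06 log units; within the scatter), a change held within the scatter.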

Compound 4, solubility: 4800 nM
Beside the measured number, compound 4's estimate is 2.3-fold (0.36 log units) above it; the measured number falls inside the stated range.
By their numbers in this assay, from the lowest: compounds 4, 2, 1 and 3 (each within the scatter of the next, the first and the last beyond it).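

For the compounds shown here, until now the only step beyond the scatter was a 3.6-fold higher number from compound 2 to compound 3 (0.56 log units; beyond the scatter), which left the ring group itself unchanged; the new step is the first to touch that group, on a saturated chain carbon bound to an aromatic carbon and a saturated chain carbon. In this assay the change gives a 2.6-fold lower number from compound 1 to compound 4 (0.42 log units; beyond the scatter), so the number at this place responds to the group even though the entering and leaving groups have the same hydrogen-bond donor and acceptor counts, the same number of double bonds outside aromatic rings and the same kind of five-membered non-aromatic ring. No measurement at hand accounts for this step, which stands as an observation only.

From the compounds shown here alone, the two groups differ at once in 1 sulfur against a third oxygen and in 4 carbon against 5 carbon, so the share of the step belonging to each difference stays open, as does whether the step carries over to the chain of compound 3. Also open, going by these compounds, is how the number would respond at this place to a group of another kind, such as an amine or a carboxylic acid, on the shared core.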